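This account rests on a few compounds, and the source may have more. Where it says the series, first, only, none or still open, it means among the compounds named here.

Measured so far in a functional assay on CCRF-CEM cells (Homo sapiens) for antiproliferative activity, read by trypan blue exclusion, with a stated time of 72 h; a lower number here means a stronger inhibitor, a higher number a weaker inhibitor:
- compound 1 `CC(Br)C(=O)Nc1cc(C(=O)NC(N)=O)ccc1F` gives 3130 nM
- compound 2 `NC(=O)NC(=O)c1ccc(F)c(NC(=O)CBr)c1` gives 2290 nM
- compound 3 `Cc1c(NC(=O)C(C)Cl)cccc1C(=O)NC(N)=O` gives only a limit of the assay, > 20000 nM

Compounds 1 and 2 share a core and differ by one change, (hydrogen in place of methyl on a saturated chain carbon bound to a bromine atom and a carbonyl carbon). The step it made is a 1.4-fold lower number from compound 1 to compound 2 (0.14 log units; within the scatter). The limit for compound 3 is the same one recorded in the limit of > 20000 nM in this assay, at which 1 of the 3 values shown sits. The difference between the core of compound 3 and the core of compound 1 is not broken down here.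

Compound 4 `Cc1c(NC(=O)CCl)cccc1C(=O)NC(N)=O` is not yet measured. It differs from compound 3 by hydrogen in place of methyl on a saturated chain carbon bound to a carbonyl carbon and a chlorine atom. Within the data shown here, this is the same kind of change as the one from compound 1 to compound 2, though the place is not the same: in the measured pair the chain carbon is bound to a bromine atom and a carbonyl carbon, while here it is bound to a carbonyl carbon and a chlorine atom. Among the measured compounds shown here, since the only measured instance of this change stayed within the scatter, and since compound 3 itself gives only a limit, compound 4 is expected to sit in the same region, with a step that the limit leaves unreadable from compound 3 to compound 4 in this assay. Compound 4 is estimated at 22000 nM, within 8000 nM to 60000 nM, and a limit rather than a number is the more likely outcome.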

Compound 4, half-maximal inhibitory concentration: 2700 nM
Compound 4: the middle estimate sits 8.1-fold (0.91 log units) above what was measured; the whole stated range lies above it.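

In this assay, hydrogen in place of methyl on a saturated chain carbon bound to a carbonyl carbon and a chlorine atom gives an at least 7.4-fold lower number from compound 3 to compound 4 (0.86 log units; beyond the scatter). Set beside the bromine-bearing pair, the change does not carry over from one core to the other with a single size: the same change on two cores in this assay, a 1.4-fold lower number (0.14 log units; within the scatter) from compound 1 to compound 2 and an at least 7.4-fold lower number (0.86 log units; beyond the scatter) from compound 3 to compound 4, at least 5.4-fold (0.73 log units) apart, beyond the scatter of two such steps Compound 3 gives only a limit of the assay, > 20000 nM, leaving the full size of its step unread, and the two pairs differ in halogen as well as in core, so these compounds do not show whether the core or the halogen sets the gap.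

Still open, as far as these compounds go, is whether bromine in place of chlorine on the core of compound 3, or chlorine in place of bromine on the core of compound 1, would separate those two differences. Also open, from the compounds shown here alone, is the outcome for a longer chain, such as ethyl in place of methyl, or for an amine in place of the halogen on the chain carbon.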